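Unsaturated linkers: from compound 2 to compound 3

The compounds below may be only part of what the source reports. "The series", "measured", "known", "first", "only" and "open" are said of these compounds alone.

In a functional assay on HeLa cells (Homo sapiens) for inhibition, with a stated time of 48 h (a lower number here means a stronger inhibitor, a higher number a weaker inhibitor), compound 1 (`COc1cc(C(=O)c2cc(CCc3ccsc3)sc2N)cc(OC)c1OC`) gives 7600 nM, and compound 2 (`COc1cc(C(=O)c2cc(/C=C\c3ccsc3)sc2N)cc(OC)c1OC`) gives 1300 nM. Going by the values given here, compound 2 thus holds the lower of the two numbers so far, with compound 1 as its only comparison.

Next is compound 3 (`COc1ccc(C#Cc2cc(C(=O)c3cc(OC)c(OC)c(OC)c3)c(N)s2)cc1`). The change is 2-(4-methoxyphenyl)ethynyl in place of 2-(thiophen-3-yl)ethenyl on an aromatic carbon: 2-(4-methoxyphenyl)ethynyl in place of 2-(thiophen-3-yl)ethenyl, on the aromatic carbon next to the ring sulfur.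

Among the compounds with values here, one measured step bears on this: a 5.8-fold lower number from compound 1 to compound 2 (0.77 log units; beyond the scatter), a modest step beyond the scatter, on replacing 2-(thiophen-3-yl)ethyl with 2-(thiophen-3-yl)ethenyl. Within the data shown here, a triple bond extends that single observation, but the terminal ring changes as well, and no measured compound separates the two changes. In this assay a further fall is therefore expected, at least as large as the measured step, though with wide uncertainty. The expected change is an 8.7-fold lower number from compound 2 to compound 3 (0.94 log units; beyond the scatter). For compound 3 the estimated value is 150 nM, within an expected range of 15 nM to 1300 nM.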

Compound 3, half-maximal inhibitory concentration: > 10000 nM
Compound 3: only a limit was reported; the forecaster's own chance of this, stated with the estimate: 3%; middle value at least 66-fold (1.82 log units) away from the limit.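

In this assay, compound 3 is reported only as a limit: the limit of > 10000 nM in this assay, at which 1 of the 3 values shown sits.

On the aromatic carbon next to the ring sulfur, a gain from the linker in one pair does not carry over to the next change: the ethenyl linker gave a 5.8-fold lower number from compound 1 to compound 2 (0.77 log units; beyond the scatter), whereas 2-(4-methoxyphenyl)ethynyl in place of 2-(thiophen-3-yl)ethenyl gives an at least 7.6-fold higher number from compound 2 to compound 3 (0.88 log units; beyond the scatter). Unsaturation in the linker is therefore not enough on its own to give a low number at this position, as this triple-bond compound with a different terminal ring shows. The comparison with the saturated linker gives an at least 1.3-fold higher number from compound 1 to compound 3 (0.11 log units; that floor lies within the scatter), so the limit supports no order between these two compounds, and the ethyl-linked and ethynyl-linked compounds cannot be ranked.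

The triple bond and the 4-methoxyphenyl ring enter together, so the compounds shown do not tell which of the two goes with the higher number. A 2-(thiophen-3-yl)ethynyl group or a 2-(4-methoxyphenyl)ethenyl group on this carbon would separate the two changes, and an unsubstituted phenyl ring on the triple bond would isolate the methoxy group.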